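Working notes: amine exchange from compound 3 to compound 4

This account rests on a few compounds, and the source may have more. Where it says the series, first, only, none or still open, it means among the compounds named here.

Measured compounds:
Compound 1 `Nc1ccc2cccc(OCC3CCCC3)c2n1`: in a functional assay on IMR-32 cells with melanin-concentrating hormone receptor 1 (Homo sapiens) as the target, read by fluorescence (a lower number here means a stronger inhibitor, a higher number a weaker inhibitor), compound 1 gives 2290 nM.
Compound 2 `CC(CC(C)(C)C)Oc1cccc2ccc(N3CCCCC3)nc12`: in this assay compound 2 gives only a limit, > 10000 nM.
Compound 3 `CC(CC(C)(C)C)Oc1cccc2ccc(N3CCCC3)nc12`: in this assay compound 3 gives only a limit, > 10000 nM.

Compound 3 therefore stands at the limit of > 10000 nM in this assay, at which 2 of the 3 values shown sit, which is a limit of the assay and not a number. Within the data shown here, the one measured step, a step that the two limits leave unreadable from compound 2 to compound 3, runs between two limits and its size cannot be read.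

Compound 4 `CC(CC(C)(C)C)Oc1cccc2ccc(N(C)C)nc12` differs from compound 3 by dimethylamino in place of pyrrolidin-1-yl on an aromatic carbon. Among the measured compounds shown here, no measured step bears directly on this change; the only step, a step that the two limits leave unreadable from compound 2 to compound 3, is a different exchange, also on an aromatic carbon, and is itself unreadable. In this assay no direction beyond the scatter can be expected. Compound 4 is expected near 12000 nM, between 3000 nM and 40000 nM, and most likely again only a limit. The expected step is a step that the limit leaves unreadable from compound 3 to compound 4.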

Compound 4, half-maximal inhibitory concentration: > 10000 nM
Compound 4: a limit, no number (the forecaster's own chance of this, stated with the estimate: 65%); the middle value lies beyond the limit too.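

Compound 2, compound 3 and compound 4 all stand at a limit of the assay and not at a number, so no step among them can be read: the limit of > 10000 nM in this assay, at which 3 of the 4 values shown sit.

The compounds shown leave open how piperidin-1-yl, pyrrolidin-1-yl and dimethylamino on the shared core rank in this assay.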